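A few compounds are considered here, and "the series" means these few. Any claim that something is new, unique, unknown or untested is made for them only; others in the source may bear on it.

Measured compounds in a functional assay on NCI/ADR-RES cells (Homo sapiens) for cytotoxicity, read by sulforhodamine B assay, with a stated time of 48 h, tested at 0.1 uM; a higher number here means a weaker effect of the compound at the concentration tested, a lower number a stronger effect:

compound 1 `COc1cc(-c2cc(/C=C/C(=O)c3ccc(N)cc3)[nH]n2)cc(OC)c1OC` — 110%
compound 2 `COc1cc(-c2cc(/C=C/C(=O)c3ccc(Cl)c(Cl)c3)[nH]n2)cc(OC)c1OC` — 96%
compound 3 `COc1ccc(C(=O)/C=C/c2cc(-c3cc(OC)c(OC)c(OC)c3)n[nH]2)cc1` — 97%

In this assay compound 3 stands second highest of the three numbers. Its nearest neighbour is compound 2, with the step of a number 1 percentage points higher from compound 2 to compound 3 (within the scatter) lying within the scatter, so the two values are not to be ordered. The furthest is compound 1, with a number 13 percentage points lower from compound 1 to compound 3 (beyond the scatter) beyond the scatter; likewise a number 14 percentage points lower from compound 1 to compound 2 (beyond the scatter) is beyond the scatter.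

Compound 4 `COc1cc(-c2cc(/C=C/C(=O)c3ccc(F)c(F)c3)[nH]n2)cc(OC)c1OC` is not yet measured in this assay. It differs from compound 3 by 3,4-difluorophenyl in place of 4-methoxyphenyl on a carbonyl carbon. For the measured compounds named here, the one step that bears on this change is the exchange of groups on the carbonyl carbon between compound 2 and compound 3, which gave a number 1 percentage points higher from compound 2 to compound 3 (within the scatter): a change from 3,4-dichlorophenyl to 4-methoxyphenyl moved the read-out only within the scatter. A return to a dihalogenated ring on that carbon is therefore expected to give no step beyond the scatter, with the expected step from compound 3 to compound 4 being no change at the digits printed from compound 3 to compound 4 (within the scatter). On that basis compound 4 is estimated at 97%, with a range of 85% to 110%.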

Compound 4, a percentage reported as activity, at one concentration (the size of the read-out at that concentration, not a potency): 98%
For compound 4 the middle estimate is 1 percentage points below the measured one; low and high end bracket the measured number.
By their numbers in this assay, from the lowest: compounds 2, 3 and 4 (each within the scatter of the next); then compound 1.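

In this assay, a number 1 percentage points higher from compound 3 to compound 4 (within the scatter) and a number 2 percentage points higher from compound 2 to compound 4 (within the scatter) both lie within the scatter, so 3,4-difluorophenyl, 3,4-dichlorophenyl and 4-methoxyphenyl on the carbonyl carbon cannot be told apart at this single concentration. The two dihalogenated rings are now compared directly, and exchanging fluorine for chlorine on that ring gives no readable step. Only 4-aminophenyl stands apart, and a number 12 percentage points lower from compound 1 to compound 4 (beyond the scatter) adds a third modest step beyond the scatter from that compound to a replacement group.

On these data alone, whether these groups would separate at a higher concentration remains open. So does how a carboxylic acid or a pyridine ring on the carbonyl carbon would read in this assay. Nothing available here accounts for the separate position of 4-aminophenyl.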